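Adding a second chloro to the core of compound 1

The source may hold more compounds than are shown below. What is called first, only, known or untested is meant among the compounds shown, and "the series" means these compounds.

Three benzylic chloromethyl analogues on one shared core have been measured. In a functional assay on SK-OV-3 cells (Homo sapiens) for cytotoxicity, read by sulforhodamine B assay, with a stated time of 48 h (on this read-out lower numbers stand for stronger inhibition of growth and higher numbers for weaker inhibition of growth), compound 1 `ClCc1ccc(Cn2cnc3c(Cl)ncnc32)cc1` gives 3380 nM, compound 2 `ClCc1cccc(Cn2cnc3ncnc(Cl)c32)c1` gives 10700 nM and compound 3 `ClCc1ccccc1Cn1cnc2ncnc(Cl)c21` gives 7580 nM. Compound 1 stands lowest of the three, with both gaps beyond the scatter, so it shows the strongest inhibition of growth in this assay. Compound 4 `ClCc1ccc(Cn2cnc3c(Cl)nc(Cl)nc32)cc1` differs from compound 1 by chloro in place of hydrogen on an aromatic carbon. Within the data shown here, no measured pair shows this change, so no step size is known; the expectation is a step from compound 1 to compound 4 of a 1.4-fold lower number from compound 1 to compound 4 (0.13 log units; within the scatter), within the scatter or slightly toward lower numbers. Compound 4 is estimated at 2500 nM, in the range 800 nM to 8000 nM.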

Compound 4, concentration for 50% growth inhibition: 13500 nM
The estimate for compound 4 lay 5.4-fold (0.73 log units) below the measured number; the whole stated range lies below it.
By their numbers in this assay, from the lowest: compound 1; then compounds 3, 2 and 4 (each within the scatter of the next).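

In this assay, chloro in place of hydrogen on an aromatic carbon between two ring nitrogen atoms gives a 4.0-fold higher number from compound 1 to compound 4 (0.60 log units; beyond the scatter), so growth inhibition weakens modestly. The earlier compounds shown here all carry hydrogen at this position and could not show that it responds to substitution. No data at hand give a reason for this step.

From the compounds shown here alone, whether the weakening belongs to chloro or to any group at this position remains open; an amine or a methoxy group there would separate the two. Going by these compounds, whether the step carries over to the analogues with the chloromethyl group placed differently also remains open.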